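A larger group on the carbonyl of compound 2

The source may hold more compounds than are shown below. What is called first, only, known or untested is meant among the compounds shown, and "the series" means these compounds.

For the measured compounds named here, in a functional assay on HepG2 cells (Homo sapiens) for antiproliferative activity, read by MTT assay, with a stated time of 48 h (on this read-out higher numbers stand for weaker inhibition and lower numbers for stronger inhibition), compound 1 (`CCn1c(C(=O)NCCN)ccc1C(CC)(CC)c1ccc(OCCC(O)(CC)CC)c(C)c1`) gives 1590 nM and holds the only true number in this small set. Compound 2 (`C#CC(C)OC(=O)c1ccc(C(CC)(CC)c2ccc(OCCC(O)(CC)CC)c(C)c2)n1CC`) stands only at a limit of > 50000 nM and has no number of its own. Going by the values given here, the one measured step is an at least 31-fold higher number from compound 1 to compound 2 (1.49 log units; beyond the scatter) and comes with (1-methylprop-2-yn-1-yl)oxy in place of (2-aminoethyl)amino on a carbonyl carbon.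

Compound 3 (`CCC(C)C(NC(=O)c1ccc(C(CC)(CC)c2ccc(OCCC(O)(CC)CC)c(C)c2)n1CC)C(=O)OC`) differs from compound 2 at that same carbonyl carbon, and the change is a group of 10 heavy atoms (7 carbon, 1 nitrogen, 2 oxygen; no ring) in place of a group of 5 heavy atoms (4 carbon, 1 oxygen; no ring), on a carbonyl carbon with the shared core left as it is. The entering group holds nitrogen but is not the (2-aminoethyl)amino of compound 1, so the large step above bears on it only in part. Compound 3 is therefore expected to sit much nearer compound 2 than compound 1, with at most a modest move to a lower number in this assay and possibly none that can be resolved. The expected move is an at least 1.6-fold lower number from compound 2 to compound 3 (0.22 log units; that floor lies within the scatter) and it is estimated against a limit and not against a number. In this assay the estimated value for compound 3 is 30000 nM within an expected range from 8000 nM to 90000 nM and a report as a limit would not be surprising.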

Compound 3, half-maximal inhibitory concentration: > 50000 nM
Compound 3 gave a limit, no number; the forecaster's own chance of this, stated with the estimate: 55%; middle value at least 1.6-fold (0.22 log units) from the limit.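

Compound 3 keeps the amide-type nitrogen of compound 1, yet the step is an at least 31-fold higher number from compound 1 to compound 3 (1.49 log units; beyond the scatter) in this assay, with a different group on that nitrogen. The earlier step had replaced the (2-aminoethyl)amino group as a whole, so it could not separate the nitrogen on the carbonyl carbon from the rest of that group, whereas this comparison shows that the amide-type nitrogen alone does not keep the number of compound 1. The step from compound 2 to compound 3 cannot be read, and no order can be given to the two compounds, because both stand at the same limit: the limit of > 50000 nM in this assay, at which 2 of the 3 values shown sit.

The compounds shown leave open how far the amine of compound 1 accounts for its number, and whether an amine on a longer chain on the amide-type nitrogen would give a true value in this assay. They also leave open whether a carboxylic acid in place of the methyl ester of compound 3 would give a number and not a limit.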